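A Methyl Added to the Amide of Compound 2

The source may report more compounds than this note shows. Statements on the series, on what has been measured and on what is new or still open speak of the compounds shown alone.

Compound 1 `CC(C)c1cc(C(=O)Nc2cccc(NC(=O)CCCCCCC(=O)NO)c2)c(O)cc1O`, compound 2 `CC(C)c1cc(C(=O)Nc2ccc(NC(=O)CCCCCCC(=O)NO)cc2)c(O)cc1O` and compound 3 `CC(C)c1cc(C(=O)Nc2ccccc2NC(=O)CCCCCCC(=O)NO)c(O)cc1O` are close structural relatives. In a functional assay on A549 cells (Homo sapiens) for inhibition, read by sulforhodamine B assay, with a stated time of 48 h (a higher number here means a weaker inhibitor of growth, a lower number a stronger inhibitor of growth), compound 1 gives > 10000 nM, which is a limit and not a number. Compound 2 gives > 10000 nM, also a limit. Compound 3 gives > 10000 nM, again a limit. Compound 2 therefore stands with its relatives at the limit of > 10000 nM in this assay, at which 3 of the 3 values shown sit.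

Compound 4 `CC(C)c1cc(C(=O)N(C)c2ccc(NC(=O)CCCCCCC(=O)NO)cc2)c(O)cc1O` carries methyl in place of hydrogen on an amide-type nitrogen. Within the data shown here, no measured pair shows what this change does, so any forecast is uncertain. The expected at least 1.4-fold lower number from compound 2 to compound 4 (0.15 log units; that floor lies within the scatter) is small and points towards stronger growth inhibition, and compound 4 may well stay at the limit. For compound 4, the estimated value is 7000 nM, with an expected range from 1500 nM to 20000 nM.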

Compound 4, concentration for 50% growth inhibition: 770 nM
The estimate for compound 4 lay 9.1-fold (0.96 log units) above the measured number; the measured number lies below the stated range.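

Methyl in place of hydrogen on the amide-type nitrogen gives an at least 12-fold lower number from compound 2 to compound 4 (1.11 log units; beyond the scatter) in this assay, so this nitrogen is a place where a small change can matter greatly. The earlier compounds could not show this, since changing where the groups sit on the central ring left every result at a limit and not a number: the limit of > 10000 nM in this assay, at which 3 of the 4 values shown sit.

As far as these compounds go, the true size of the step stays unknown, since compound 2 has only a limit. Also open, from the compounds shown here alone, is whether an ethyl group on this nitrogen would act like methyl, and why methyl acts as it does.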